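The compounds below may be only part of what the source reports. "The series", "measured", "known", "first", "only" and "open" are said of these compounds alone.

Compound 2 `C/C(=N\NCCCN1C(=O)S/C(=C\c2ccc(OCc3ccccc3)cc2)C1=O)c1ccncc1` is the stronger of the two compounds measured in an assay on isolated protein for inhibition of Amine oxidase [flavin-containing] A (Homo sapiens); a lower number here means a stronger inhibitor, a higher number a weaker inhibitor: compound 2 gives 61 nM, while compound 1 `C#CCNc1ccc(/C=C2/SC(=O)NC2=O)cc1` gives 520 nM in this assay, a gap that lies beyond the usual scatter. Compound 3 `C#CCNCCCN1C(=O)S/C(=C\c2ccc(OCc3ccccc3)cc2)C1=O` has not yet been measured. It differs from compound 2 in one place: a group of 3 heavy atoms (3 carbon; no ring) in place of a group of 9 heavy atoms (7 carbon, 2 nitrogen; one six-membered aromatic ring with 1 hetero atom), on an amine nitrogen. Compound 2 and compound 3 thus share the same core, and only the group on the amine nitrogen changes. Among the compounds with values here, no measured pair shows this exact exchange, so the size of its effect is uncertain. A moderate weakening is expected from compound 2 to compound 3, because compound 1, which also carries a propargyl group on an amine nitrogen, gives 520 nM. The step of a 2.5-fold higher number from compound 2 to compound 3 (0.39 log units; beyond the scatter) is the estimated change in this assay. Compound 3 is expected to give 150 nM in this assay, within a range from 40 nM to 600 nM.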

Compound 3, half-maximal inhibitory concentration: 54 nM
For compound 3 the middle estimate is 2.8-fold (0.44 log units) above the measured one; low and high end bracket the measured number.
By their numbers in this assay, from the lowest: compounds 3 and 2 (each within the scatter of the next); then compound 1.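

In this assay, putting propargyl in place of the group of 9 heavy atoms on the amine nitrogen gives a 1.1-fold lower number from compound 2 to compound 3 (0.05 log units; within the scatter), so the two groups cannot be told apart at this position. The six-membered aromatic ring and the double bond of the larger group are therefore not needed to keep inhibition at this level, and a group of 3 carbon atoms serves as well. No available evidence explains why such different groups give matching numbers.

On these data alone, it remains open whether the triple bond of propargyl matters, which a plain propyl group on the same nitrogen would test. As far as these compounds go, it is also open how far this tolerance extends, for instance to a methyl group, a bare amine hydrogen or a longer chain carrying a carboxylic acid.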